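Shortening the chain to a single piperidine carbonyl

This account rests on a few compounds, and the source may have more. Where it says the series, first, only, none or still open, it means among the compounds named here.

The account concerns compound 2 `CS(=O)(=O)c1ccc(C(=O)NCCCC(=O)N2CCCCC2)cc1[N+](=O)[O-]`. In an assay on isolated protein for inhibition of thyroid hormone receptor alpha (Homo sapiens), read by fluorescence polarization (a lower number here means a stronger inhibitor, a higher number a weaker inhibitor), compound 2 gives > 60000 nM, which is a limit of the assay and not a number. Compound 1 `CC1CCN(C(=O)CCNC(=O)c2ccc(S(C)(=O)=O)c([N+](=O)[O-])c2)CC1` gives in this assay > 60000 nM, again a limit. Compound 3 `CC1CCN(C(=O)CCCNC(=O)c2ccc(S(C)(=O)=O)c([N+](=O)[O-])c2)CC1` gives in this assay > 60000 nM, also a limit. The position of compound 2 is thus fixed only by the limit of > 60000 nM in this assay, at which 3 of the 3 values shown sit, so it stands where every measured compound stands and no order among the three is readable. The steps that touch compound 2 are a step that the two limits leave unreadable from compound 1 to compound 2 and a step that the two limits leave unreadable from compound 2 to compound 3, and neither yields a size. Compound 4 `CS(=O)(=O)c1ccc(C(=O)NCCC(=O)N2CCCCC2)cc1[N+](=O)[O-]` differs from compound 2 by (piperidin-1-yl)carbonyl in place of ((piperidin-1-yl)carbonyl)methyl on a saturated chain carbon, two bonds along the chain from an amide-type nitrogen. Both measured steps alter the same stretch of chain and both are unreadable, so no shift beyond the scatter can be foreseen in either direction, and a further limit is the likeliest outcome. Compound 4 is therefore expected to give 100000 nM in this assay, within 30000 nM to 300000 nM, which means an expected step that the limit leaves unreadable from compound 2 to compound 4.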

Compound 4, half-maximal inhibitory concentration: > 60000 nM
Compound 4 ended at the assay's limit; the forecaster's own chance of this, stated with the estimate: 85%; the middle value lies beyond the limit too.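

No size can be read from the new steps joining compound 4 to compound 2 and compound 1, as each pair gives only two limits. The compounds leave open whether chain length or the ring methyl affects inhibition in this assay at all, with all of them at one position: the limit of > 60000 nM in this assay, at which 4 of the 4 values shown sit.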